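The source may report more compounds than this note shows. Statements on the series, on what has been measured and on what is new or still open speak of the compounds shown alone.

Three compounds share one core, and they differ only in the group on the amine nitrogen in the ring. Compound 1 `CCN1CCc2nc(C#Cc3ccccc3)sc2C1` carries an ethyl there; in an assay on HEK293 cells for negative allosteric modulation of metabotropic glutamate receptor 5 (Homo sapiens), read by FLIPR, with a stated time of 1 h (a lower number here means a stronger inhibitor, a higher number a weaker inhibitor), compound 1 gives 1200 nM. Compound 2 `C(#Cc1nc2c(s1)CN(C1CCCCC1)CC2)c1ccccc1` carries a cyclohexyl instead. In this assay compound 2 reaches only the limit > 10000 nM, which is a boundary of the measurement and not a number. Compound 3 `CC1CC(C(=O)N2CCc3nc(C#Cc4ccccc4)sc3C2)C1` carries a (3-methylcyclobutyl)carbonyl on that nitrogen. In this assay compound 3 likewise sits at the limit > 10000 nM, again a boundary rather than a number. The steps are an at least 8.3-fold higher number from compound 1 to compound 2 (0.92 log units; beyond the scatter) and an at least 8.3-fold higher number from compound 1 to compound 3 (0.92 log units; beyond the scatter), while a step that the two limits leave unreadable from compound 2 to compound 3. Two of the three values rest at the limit of > 10000 nM in this assay, at which 2 of the 3 values shown sit.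

Compound 4 `CC1CCC(C(=O)N2CCc3nc(C#Cc4ccccc4)sc3C2)CC1` differs from compound 3 by 4-methylcyclohexyl in place of 3-methylcyclobutyl on a carbonyl carbon. Going by the values given here, no measured step follows this particular change, so nothing tells how the amide carrying a larger ring behaves. What the numbers do show is that compound 3 lies beyond the measurable range, and the swap to compound 4 leaves the amide carbonyl and the core as they are. Compound 4 is therefore expected to stay near that boundary, with a step that the limit leaves unreadable from compound 3 to compound 4 as the estimated step. Compound 4 is estimated at 15000 nM, within a range from 5000 nM to 50000 nM.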

Compound 4, half-maximal inhibitory concentration: > 10000 nM
Compound 4: no number, only a limit (the forecaster's own chance of this, stated with the estimate: 75%); the middle value lies beyond the limit too.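

In this assay compound 4 gives only a limit, > 10000 nM, and not a number. Going by these compounds alone, compound 3 sits at a limit as well, so no step between compound 3 and compound 4 can be read. The compounds shown leave open whether 4-methylcyclohexyl and 3-methylcyclobutyl on that carbonyl carbon differ at all in this assay: the limit of > 10000 nM in this assay, at which 3 of the 4 values shown sit.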